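A few compounds are considered here, and "the series" means these few. Any claim that something is new, unique, unknown or untested is made for them only; others in the source may bear on it.

In a functional assay on A549 cells (Homo sapiens) for antiproliferative activity, read by MTT assay, with a stated time of 48 h (on this read-out lower numbers stand for stronger inhibition of growth and higher numbers for weaker inhibition of growth), compound 1 `COc1ccc(/C=C2\Cc3c(cc(OC)c(OC)c3OC)C2=O)cc1[N+](=O)[O-]` gives 770 nM, and its bromo counterpart, compound 3 `COc1ccc(/C=C2\Cc3c(cc(OC)c(OC)c3OC)C2=O)cc1Br`, gives 410 nM. These two numbers are the only exact ones so far, and they lie within the scatter of each other. For compound 2 `COc1cc2c(c(OC)c1OC)C/C(=C\c1cc(OC)c(OC)c(OC)c1OC)C2=O`, the assay reports a limit and not a number: > 10000 nM.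

The next compound, compound 4 `COc1ccc(/C=C2\Cc3c(cc(OC)c(OC)c3OC)C2=O)cc1N`, keeps the core of compound 1 and carries amino in place of nitro on an aromatic carbon. For the measured compounds named here, only one measured step bears on this change, the swap at the same place from nitro to bromo: a 1.9-fold lower number from compound 1 to compound 3 (0.27 log units; within the scatter). That single step replaces nitro with a different group, so it is a loose guide to what amino will do. Still, it gives no sign that this place demands nitro, so a step beyond the scatter is not expected. The estimated step is a 1.9-fold lower number from compound 1 to compound 4 (0.28 log units; within the scatter). For compound 4, the expected value is 400 nM, with an estimated range from 100 nM to 1500 nM.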

Compound 4, concentration for 50% growth inhibition: 212 nM
Compound 4: middle estimate off by 1.9-fold (0.28 log units), on the high side; measured number inside the range.
By their numbers in this assay, from the lowest: compounds 4, 3 and 1 (each within the scatter of the next, the first and the last beyond it). At a limit, above all of these: compound 2.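

In this assay, for the compounds shown here, amino in place of nitro gives a 3.6-fold lower number from compound 1 to compound 4 (0.56 log units; beyond the scatter), the first step at this place on the ring, ortho to a methoxy group, that lies beyond the scatter, so nitro is not required here for inhibition of growth. Amino in place of bromo gives a 1.9-fold lower number from compound 3 to compound 4 (0.29 log units; within the scatter), so these two groups cannot be told apart by this read-out, and amino separates from nitro where bromo did not. Nothing measured here accounts for the step from nitro to amino.

Still open, from the compounds shown here alone, is whether the nitrogen can carry more atoms, as in a dimethylamino group or an acetamide, and keep a number close to that of compound 4. A hydroxyl group or a carboxylic acid at this same place also remains untested in the compounds shown.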